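Replacing a bromophenyl with a chlorinated phenol on a chalcone

The source may report more compounds than this note shows. Statements on the series, on what has been measured and on what is new or still open speak of the compounds shown alone.

Of the compounds shown here, three sharing one core have been tested in a functional assay on SK-OV-3 cells (Homo sapiens) for antiproliferative activity, read by MTT assay, with a stated time of 24 h; on this read-out higher numbers stand for weaker inhibition and lower numbers for stronger inhibition. Compound 1 `COc1ccc(C(=O)/C=C/c2ccc(Br)cc2)c2c1C=CC(C)(C)O2` sits at the limit of this assay, giving > 10000 nM, which is a boundary of the measurement rather than a number. Compound 3 `COc1cc(/C=C/C(=O)c2ccc(OC)c3c2OC(C)(C)C=C3)cc(OC)c1O` also returns a limit, > 10000 nM. Only compound 2 `COc1ccc(C(=O)/C=C/c2ccc3ccccc3c2)c2c1C=CC(C)(C)O2` yields a number in this assay, at 7650 nM. So compound 1 stands among the two values that reach the limit, and the whole set shows weak inhibition: the limit of > 10000 nM in this assay, at which 2 of the 3 values shown sit.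

Compound 4 `COc1ccc(C(=O)/C=C/c2cc(Cl)ccc2O)c2c1C=CC(C)(C)O2` has not yet been measured in this assay. It differs from compound 1 in one place (5-chloro-2-hydroxyphenyl in place of 4-bromophenyl on a double-bonded chain carbon bound to a double-bonded chain carbon). The entering group carries a hydroxyl that the leaving group lacks, and the halogen changes from bromine to chlorine. Within the data shown here, no measured pair in this set isolates such a change, so its effect is unknown from these data.

Given that compound 1 gives > 10000 nM, compound 4 is expected to remain a weak inhibitor, with a step of an at least 1.2-fold lower number from compound 1 to compound 4 (0.09 log units; that floor lies within the scatter) that is small and within or close to the usual scatter. The estimate for compound 4 is therefore 8000 nM, with a likely range from 3000 nM to 20000 nM.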

Compound 4, half-maximal inhibitory concentration: 6270 nM
For compound 4 the middle estimate is 1.3-fold (0.11 log units) above the measured one; the range from low to high includes it.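

Among these compounds, the change from 4-bromophenyl to 5-chloro-2-hydroxyphenyl gives the first step that can be read at this place on the chain, an at least 1.5-fold lower number from compound 1 to compound 4 (0.20 log units; that floor lies within the scatter), and it brings a hydroxyl and a different halogen together in a single change. From the compounds shown here alone, compound 1 gives > 10000 nM, which is a limit of the assay and not a number, so the step has only a floor and its true size stays unknown. Even with this change, the set as a whole still sits at the weak end of this assay: the limit of > 10000 nM in this assay, at which 2 of the 4 values shown sit.

Whether the hydroxyl or the chlorine accounts for the step stays open, as the two enter together and no compound shown carries one without the other. Equally open, going by these compounds, is how a phenyl ring bearing an amine or a carboxylic acid at this place would read in this assay.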